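Acyloxy ester swap: pivalate to benzoate

The source may hold more compounds than are shown below. What is called first, only, known or untested is meant among the compounds shown, and "the series" means these compounds.

Measured so far:
compound 1 `CC(=O)O[C@@H]1OC(=O)[C@](C)(C(C)=O)[C@@H]1C` — < 0.0834 h (a limit)
compound 2 `CC(=O)[C@@]1(C)C(=O)O[C@@H](OC(=O)C(C)(C)C)[C@H]1C` — < 0.0834 h (a limit)

In an ADME assay on the whole organism (blood) for pharmacokinetics, with Mus musculus as the target (on this read-out higher numbers stand for a longer-lived compound and lower numbers for a shorter-lived compound), compound 1 gives < 0.0834 h, which is a limit of the assay. In this assay compound 2 gives < 0.0834 h, also a limit. The step that the two limits leave unreadable from compound 1 to compound 2 is therefore unreadable. Compound 3 `CC(=O)[C@@]1(C)C(=O)O[C@@H](OC(=O)c2ccccc2)[C@H]1C` differs from compound 2 by phenyl in place of tert-butyl on a carbonyl carbon. No readable measured step bears on this change, and both known values sit at the limit of < 0.0834 h in this assay, at which 2 of the 2 values shown sit. The step that the limit leaves unreadable from compound 2 to compound 3 is expected to stay unreadable. Compound 3 is expected at 0.05 h, within 0.015 h to 0.17 h.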

Compound 3, half-life: < 0.0834 h
Compound 3: no number, only a limit; the forecaster's own chance of this, stated with the estimate: 75%; the middle value does not contradict the limit.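

In this assay, compound 1, compound 2 and compound 3 all give only limits, so no step among them can be read: the limit of < 0.0834 h in this assay, at which 3 of the 3 values shown sit.

The compounds shown leave open how long each one actually lasts, and whether methyl, tert-butyl or phenyl on the carbonyl carbon makes any difference.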